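Halogen swap on the aryl ring of a diaminotriazine series

A few compounds are considered here, and "the series" means these few. Any claim that something is new, unique, unknown or untested is made for them only; others in the source may bear on it.

Measured so far in a physicochemical assay for lipophilicity; on this read-out higher numbers stand for higher lipophilicity and lower numbers for lower lipophilicity:
- compound 1 `Nc1nc(N)nc(-c2cccc(F)c2)n1`: 1.73
- compound 2 `Nc1nc(N)nc(-c2cccc(Br)c2)n1`: 2.44
- compound 3 `Nc1nc(N)nc(-c2cc(Cl)ccc2Br)n1`: 1.85

Compound 1 and compound 2 share a core and differ in one place, (fluoro in place of bromo on an aromatic carbon). This change made the step of a number 0.71 log units lower from compound 2 to compound 1 (beyond the scatter). Compound 3 carries a different aryl ring from compound 2; the difference between the two cores is not broken down here. In this assay the values of compound 3 and compound 1 lie within the usual scatter of each other, so no order between them is drawn. Compound 3 sits below compound 2 by more than the scatter.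

Compound 4 `Nc1nc(N)nc(-c2cc(Cl)ccc2F)n1` is the unmeasured member. It differs from compound 3 by fluoro in place of bromo on an aromatic carbon. For the measured compounds named here, this is the same kind of change as the one from compound 2 to compound 1, not the same: there the fluoro stands meta to a group of 8 heavy atoms, whereas in compound 4 it stands ortho to a group of 8 heavy atoms and para to a chloro group. Going by the values given here, the only measured example of this kind of change is the step from compound 2 to compound 1, and the expectation for compound 4 rests on that step alone; with the surroundings of the change differing, the range is kept wide.

From compound 3 to compound 4 a step of a number 0.65 log units lower from compound 3 to compound 4 (beyond the scatter) is expected. Compound 4 is therefore estimated at 1.2 in this assay, with a range from 0.8 to 1.6.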

Compound 4, partition coefficient: 1.81
Compound 4: middle estimate off by 0.61 log units, on the low side; measured number above the stated range.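

In this assay the replacement of bromo by fluoro on an aromatic carbon gives a number 0.04 log units lower from compound 3 to compound 4 (within the scatter), whereas the same kind of change on the other core gave a number 0.71 log units lower from compound 2 to compound 1 (beyond the scatter), so the step seen on one core did not carry over to the other in this pair of cores. For the compounds shown here, this shows that a step of this kind read on one core is not a safe basis for a forecast on another core here, but with only two pairs it does not show which difference in surroundings matters, whether the group of 8 heavy atoms to which the fluoro stands ortho or the chloro group to which it stands para, nor which of the two steps is the more usual one. No measurement at hand accounts for the difference between the two steps.

The compounds shown leave open whether a further pair with this same replacement, on a core without the chloro group, would follow the step from compound 3 to compound 4 or the step from compound 2 to compound 1. As far as these compounds go, they also carry only halogens on the aryl ring, so how an amine or a carboxylic acid in the same place would read in this assay remains open.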